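The source may hold more compounds than are shown below. What is called first, only, known or untested is meant among the compounds shown, and "the series" means these compounds.

Of the compounds shown here, three sharing a common core have been measured in a functional assay on MDA-MB-231 cells (Homo sapiens) for antiproliferative activity, read by MTT assay, with a stated time of 24 h (on this read-out lower numbers stand for stronger inhibition and higher numbers for weaker inhibition), and a fourth awaits its turn. Compound 1 `COc1ccc(-c2cc(/C=C/C(=O)c3ccc(C)cc3)nc3cc(-c4ccccc4)nn23)cc1OC` gives 19800 nM in this assay. Compound 2 `COc1ccc(C(=O)/C=C/c2cc(-c3ccc(OC)c(OC)c3)n3nc(-c4ccccc4)cc3n2)cc1` gives 13900 nM. Compound 3 `COc1ccc(/C=C/C(=O)c2cc(-c3cc(OC)c(OC)c(OC)c3)n3nc(-c4ccccc4)cc3n2)cc1` gives 16500 nM. The three numbers sit close together: the difference between compound 3 and compound 2, and between compound 3 and compound 1, stays within the scatter, so no order among them can be read.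

Compound 1 and compound 2 differ by one change, (methyl in place of methoxy on an aromatic carbon), and the step it made was a 1.4-fold higher number from compound 2 to compound 1 (0.15 log units; within the scatter). The difference between the core of compound 2 and the core of compound 3 is not broken down here.

The unmeasured compound 4 `COc1cc(-c2cc(C(=O)/C=C/c3ccc(C)cc3)nc3cc(-c4ccccc4)nn23)cc(OC)c1OC` stands to compound 3 as compound 1 stands to compound 2: the change is methyl in place of methoxy on an aromatic carbon, at the same place, the same change. Because the measured instance of this change gave a 1.4-fold higher number from compound 2 to compound 1 (0.15 log units; within the scatter), a step of about the same small size is expected here, and compound 3 at 16500 nM is the starting point. The step from compound 3 to compound 4 is therefore estimated as a 1.3-fold higher number from compound 3 to compound 4 (0.10 log units; within the scatter). On that basis compound 4 is expected to give 21000 nM in this assay, with the likely range running from 8000 nM to 50000 nM.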

Compound 4, half-maximal inhibitory concentration: 18600 nM
The estimate for compound 4 lay 1.1-fold (0.05 log units) above the measured number, within the range that was stated.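

In this assay, putting 4-methylphenyl in place of 4-methoxyphenyl gave a 1.1-fold higher number from compound 3 to compound 4 (0.05 log units; within the scatter), so this second instance of the change is again a step that cannot be told apart from repeat measurement. Set beside the earlier instance, the change carries from one core to the other without a difference that can be read, and in both cases it stays small: the same change on two cores in this assay, a 1.4-fold higher number (0.15 log units; within the scatter) from compound 2 to compound 1 and a 1.1-fold higher number (0.05 log units; within the scatter) from compound 3 to compound 4, 1.3-fold (0.10 log units) apart, within the scatter of two such steps. Among the compounds shown here, this shows only that the swap stayed within the scatter on these two cores; it does not establish a real effect of the change in either direction, and two pairs with such small steps cannot show that it would behave in the same way on any other core.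

The compounds shown leave open whether any other group at this place, para to a large group, such as a chlorine atom, a hydroxyl, an amine or a carboxylic acid, would move the number beyond the scatter. They also leave open whether a step of any size would carry between cores in the way this small one does, since all four numbers sit close together.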